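Two dichloro and dihydroxy benzyl analogues, then a third

The source may hold more compounds than are shown below. What is called first, only, known or untested is meant among the compounds shown, and "the series" means these compounds.

Measured in a functional assay on G-361 cells (Homo sapiens) for antiproliferative activity, with a stated time of 72 h; a higher number here means a weaker inhibitor, a lower number a stronger inhibitor:
Compound 1 `OC[C@H]1O[C@@H](n2cnc3c(NCc4ccc(Cl)cc4Cl)ncnc32)[C@H](O)[C@@H]1O`: 128000 nM
Compound 2 `OC[C@H]1O[C@@H](n2cnc3c(NCc4cc(O)cc(O)c4)ncnc32)[C@H](O)[C@@H]1O`: > 166000 nM, a limit

Compound 2 stands at the limit of > 166000 nM in this assay, at which 1 of the 2 values shown sits, which is a limit and not a number. Compound 3 `Cc1ccc(O)c(CNc2ncnc3c2ncn3[C@@H]2O[C@H](CO)[C@@H](O)[C@H]2O)c1` differs from compound 2 as follows: 2-hydroxy-5-methylphenyl in place of 3,5-dihydroxyphenyl on a saturated chain carbon bound to a nitrogen on an aromatic ring. Going by the values given here, the one measured step at this place is an at least 1.2-fold higher number from compound 1 to compound 2 (0.11 log units; that floor lies within the scatter). Among the compounds with values here, with that small floor as the only guide, no step beyond the scatter is expected in this assay, and no direction can be called. The expected step is an at least 1.2-fold lower number from compound 2 to compound 3 (0.10 log units; that floor lies within the scatter). For compound 3 the estimated value is 130000 nM, with an expected range of 35000 nM to 300000 nM.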

Compound 3, half-maximal inhibitory concentration: > 166000 nM
Compound 3: only a limit was reported; the forecaster's own chance of this, stated with the estimate: 45%; middle value at least 1.2-fold (0.10 log units) from the limit.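

In this assay compound 3 gives > 166000 nM, a limit and not a number, and that limit is now shared: the limit of > 166000 nM in this assay, at which 2 of the 3 values shown sit.

The step between compound 2 and compound 3 cannot be read, as both values are limits. Against 2,4-dichlorophenyl, the 2-hydroxy-5-methylphenyl group gives an at least 1.2-fold higher number from compound 1 to compound 3 (0.11 log units; that floor lies within the scatter), so no real difference can be claimed and its true size remains unknown.

The compounds shown leave open whether any group at this place can give a clearly lower number. An aminophenyl group, a carboxyphenyl group or a longer chain could test this.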